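Ester to Dimethylamide on a Methoxy-Bearing Chain

The source may hold more compounds than are shown below. What is called first, only, known or untested is meant among the compounds shown, and "the series" means these compounds.

Compound 1, `CCC(C)OC(=O)/C=C(C)/C=C/CC(C)CCCC(C)C`: 7.69 
Compound 2, `CCC(C)OC(=O)/C=C(C)/C=C/CC(C)CCCC(C)(C)OC`: 6.49 
Compound 3, `COC(CCC(C)C/C=C/C(C)=C/C(=O)OC(C)C)C(C)C`: 5.95 

In a physicochemical assay for lipophilicity (on this read-out lower numbers stand for lower lipophilicity and higher numbers for higher lipophilicity), compound 2 stands second highest of the three, with compound 3 nearest and compound 1 furthest. Going by the values given here, the one measured step, a number 1.20 log units lower from compound 1 to compound 2 (beyond the scatter), concerns a different place and gives no direct guide. Compound 4, `COC(C)(C)CCCC(C)C/C=C/C(C)=C/C(=O)N(C)C`, differs from compound 2 in one place: dimethylamino in place of sec-butoxy on a carbonyl carbon. Among the compounds with values here, no measured pair bears on this change, so the expectation rests on the change alone. It is expected to lower the number clearly, by about a number 1.89 log units lower from compound 2 to compound 4 (beyond the scatter). Compound 4 is therefore estimated at 4.6, within 3.9 to 5.3.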

Compound 4, partition coefficient: 3.74
Estimate against measurement, compound 4: 0.86 log units above; the measured number lies below the stated range.
By their numbers in this assay, from the lowest: compound 4; then compound 3; then compound 2; then compound 1.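

In this assay, going by these compounds alone, replacing sec-butoxy with dimethylamino on a carbonyl carbon gives a number 2.75 log units lower from compound 2 to compound 4 (beyond the scatter), the first reading of a change at this position, since compound 1, compound 2 and compound 3 all carry an ester there. No measurement shown accounts for the size of this step.

Still open, as far as these compounds go, is how methylamino or a carboxylic acid on that carbonyl carbon would read. From the compounds shown here alone, it is also open whether the same change would give a similar step on the chain of compound 1, which lacks the methoxy group.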